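From Methoxy to Anilino on the Carbonyl Carbon

The source may report more compounds than this note shows. Statements on the series, on what has been measured and on what is new or still open speak of the compounds shown alone.

Measured so far:
compound 1, `O=C(COc1ccc(Oc2ccccc2)cc1)Cn1ncc2ccccc21`: 2600 nM
compound 2, `COC(=O)Nc1ccc2c(cnn2CC(=O)COc2ccc(Oc3ccccc3)cc2)c1`: 4000 nM

Both compounds were tested in an assay on microsomes from brain for inhibition of Fatty-acid amide hydrolase 1 (Rattus norvegicus), read by fluorescence and HPLC, with a stated time of 45 min; on this read-out lower numbers stand for stronger inhibition and higher numbers for weaker inhibition. On the numbers shown, compound 2 sits at the larger of the two values, but the step of a 1.5-fold higher number from compound 1 to compound 2 (0.19 log units; within the scatter) lies within the scatter, so the two compounds cannot be told apart with confidence. Going by the values given here, that single step concerns the (methoxycarbonyl)amino group added to an aromatic carbon and is the only measured comparison available.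

Compound 3, `O=C(COc1ccc(Oc2ccccc2)cc1)Cn1ncc2cc(NC(=O)Nc3ccccc3)ccc21`, differs from compound 2 in one place: anilino in place of methoxy on a carbonyl carbon. Among the compounds with values here, no measured step covers this particular change, since the one step on record touches a different part of the molecule and was within the scatter anyway. In this assay, therefore, the expectation for compound 3 rests mainly on the value of compound 2 itself, with a wide allowance in both directions and a slight lean towards a smaller number. Compound 3 is estimated at 2500 nM, with a plausible range from 600 nM to 10000 nM. The expected step is a 1.6-fold lower number from compound 2 to compound 3 (0.20 log units; within the scatter).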

Compound 3, half-maximal inhibitory concentration: 6000 nM
Compound 3: the middle estimate sits 2.4-fold (0.38 log units) below what was measured, within the range that was stated.
By their numbers in this assay, from the lowest: compounds 1, 2 and 3 (each within the scatter of the next, the first and the last beyond it).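

In this assay, putting anilino in place of methoxy on a carbonyl carbon gives a 1.5-fold higher number from compound 2 to compound 3 (0.18 log units; within the scatter), so even with 7 heavy atoms against 2, an added aromatic ring and a hydrogen-bond donor, the two compounds cannot be told apart. Going by these compounds alone, the comparison with the compound lacking any group at this aromatic carbon says a little more: (phenylcarbamoyl)amino in place of hydrogen gives a 2.3-fold higher number from compound 1 to compound 3 (0.36 log units; beyond the scatter), a modest weakening and the first step in this small set that clears the scatter, whereas (methoxycarbonyl)amino gave only a 1.5-fold higher number from compound 1 to compound 2 (0.19 log units; within the scatter). No supporting measurement bears on what lies behind this shift.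

Still open, on these data alone, is whether any group on this aromatic carbon can give a lower number than compound 1 does, for example a free amine in place of the whole (methoxycarbonyl)amino group. Also open, as far as these compounds go, is how the reading responds on the carbonyl carbon to a simple methylamino group, or to benzylamino, which sets a longer chain before the aromatic ring.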